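The compounds below may be only part of what the source reports. "The series", "measured", "known", "first", "only" and "open" are said of these compounds alone.

Among the compounds with values here, compound 2 `CC/C(=C(/c1ccc(/C=C/C(=O)O)cc1)c1cc2ccccc2[nH]1)c1ccc(C(F)(F)F)cc1Cl` gives 27 nM in a functional assay on MCF7 cells (Homo sapiens) for inhibition (on this read-out lower numbers stand for stronger inhibition and higher numbers for weaker inhibition), the lowest of the two numbers measured so far. Compound 1 `CC/C(=C(/c1ccc(/C=C/C(=O)O)cc1)c1cc2ccccc2[nH]1)c1cccc(C)c1` gives 140 nM in this assay, and the exchange of its ring for the chloro- and trifluoromethyl-bearing ring brought a 5.2-fold lower number from compound 1 to compound 2 (0.71 log units; beyond the scatter). Compound 3 `CC/C(=C(/c1ccc(/C=C/C(=O)O)cc1)c1cc2ccccc2[nH]1)c1ccc(Cl)cc1C(F)(F)F` differs from compound 2 in one place: 4-chloro-2-(trifluoromethyl)phenyl in place of 2-chloro-4-(trifluoromethyl)phenyl on a double-bonded chain carbon bound to a double-bonded chain carbon and a saturated chain carbon. The two therefore have the same atoms, joined differently. Within the data shown here, no measured step moves a chloro and a trifluoromethyl group around the same ring in this way; the single step known, from compound 1 to compound 2, replaced one ring by another and is a different kind of change, so it gives little guidance. With the same groups kept on the same ring, only a small change is expected, and compound 3 is estimated at 40 nM, with a range from 15 nM to 120 nM, a step of a 1.5-fold higher number from compound 2 to compound 3 (0.17 log units; within the scatter) expected to stay within or close to the scatter.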

Compound 3, half-maximal inhibitory concentration: 4 nM
Beside the measured number, compound 3's estimate is 10-fold (1.00 log units) above it; the measured number lies below the stated range.
By their numbers in this assay, from the lowest: compound 3; then compound 2; then compound 1.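

Exchanging the places of the chloro and trifluoromethyl groups on this ring, with no atom gained or lost, gives a 6.8-fold lower number from compound 2 to compound 3 (0.83 log units; beyond the scatter) in this assay, so on this chain carbon the arrangement of the two groups on the ring matters and not only their presence. The earlier step replaced one ring by another and could not show this; against the 3-methylphenyl ring, the 4-chloro-2-(trifluoromethyl)phenyl ring now gives a 35-fold lower number from compound 1 to compound 3 (1.54 log units; beyond the scatter), a larger step than a 5.2-fold lower number from compound 1 to compound 2 (0.71 log units; beyond the scatter). Nothing at hand explains why the arrangement changes the number.

From the compounds shown here alone, it remains open whether a ring carrying only the chloro or only the trifluoromethyl group would give a similar number. Also open, going by these compounds, is what a bromo or a nitrile group would do in place of the chloro.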